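Aryl swap on the aromatic nitrogen of the shared core

This account rests on a few compounds, and the source may have more. Where it says the series, first, only, none or still open, it means among the compounds named here.

The series shares one core and differs at the aryl group on an aromatic nitrogen and in the length of the chain. In a functional assay on MCF7 cells (Homo sapiens) for inhibition, read by MTT assay, with a stated time of 72 h (on this read-out lower numbers stand for stronger inhibition and higher numbers for weaker inhibition), compound 1 `COc1cc2c(Oc3ccc(NC(=O)c4nn(-c5ccccc5)cc(C)c4=O)cc3F)ccnc2cc1OCCCCCC(=O)NO` gives 2330 nM, compound 2 `COc1cc2c(Oc3ccc(NC(=O)c4nn(-c5ccccc5)ccc4=O)cc3)ccnc2cc1OCCCC(=O)NO` gives 7410 nM, and compound 3 `COc1cc2c(Oc3ccc(NC(=O)c4nn(-c5cccc(C)c5)cc(C)c4=O)cc3)ccnc2cc1OCCCCCCC(=O)NO` gives 1680 nM. Compound 3 holds the lowest of the three numbers; its gap to compound 1 lies within the scatter, its gap to compound 2 beyond it, so compound 3 and compound 1 cannot be separated here. Compound 4 `COc1cc2c(Oc3ccc(NC(=O)c4nn(-c5ccc(F)c(Cl)c5)cc(C)c4=O)cc3)ccnc2cc1OCCCCCCC(=O)NO` differs from compound 3 in one place: 3-chloro-4-fluorophenyl in place of 3-methylphenyl on an aromatic nitrogen. Within the data shown here, no measured pair carries this kind of change, so no step size can be read from the data. The step is expected to stay within the scatter, as a 1.1-fold lower number from compound 3 to compound 4 (0.05 log units; within the scatter). Compound 4 is estimated at 1500 nM, with a range from 600 nM to 4000 nM.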

Compound 4, half-maximal inhibitory concentration: 2200 nM
Compound 4: middle estimate off by 1.5-fold (0.17 log units), on the low side, within the range that was stated.
By their numbers in this assay, from the lowest: compounds 3, 4 and 1 (each within the scatter of the next); then compound 2.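

In this assay, among these compounds, the change to 3-chloro-4-fluorophenyl from 3-methylphenyl on the aromatic nitrogen gives a 1.3-fold higher number from compound 3 to compound 4 (0.12 log units; within the scatter) and is the first step readable at this position. The position therefore takes chlorine and fluorine on the aryl ring in place of the methyl group with no difference separable from the scatter. Nothing measured here bears on why this is so. Still open, on these data alone, is whether a carboxylic acid or an amine on this aryl ring would give a step beyond the scatter. Also open, as far as these compounds go, is whether this swap gives a similar step on a shorter chain.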